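Swapping an imidazole amide for a fluorophenyl amide

The source may report more compounds than this note shows. Statements on the series, on what has been measured and on what is new or still open speak of the compounds shown alone.

Three measured compounds share one core. Compound 1 `Cn1c(-c2ccc(Cl)cc2)cnc1NC(=O)c1ccc(F)cc1` pairs a 4-chlorophenyl group with a 4-fluorophenyl amide; in a toxicity assay on THP-1 cells (Homo sapiens) for inhibition (on this read-out higher numbers stand for lower toxicity in this test and lower numbers for higher toxicity in this test), compound 1 gives 37000 nM. Compound 2 `Cn1c(-c2ccc(Cl)cc2)cnc1NC(=O)c1ncc[nH]1` keeps the 4-chlorophenyl group but carries a 1H-imidazol-2-yl amide, and in this assay compound 2 gives 52000 nM. Compound 3 `Cn1c(-c2cccc(Cl)c2)cnc1NC(=O)c1ncc[nH]1` carries the same 1H-imidazol-2-yl amide on a core that differs from that of compound 2 as follows: 3-chlorophenyl in place of 4-chlorophenyl on an aromatic carbon. In this assay compound 3 gives 55000 nM.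

The change from compound 2 to compound 1 is 4-fluorophenyl in place of 1H-imidazol-2-yl on a carbonyl carbon; it made a 1.4-fold lower number from compound 2 to compound 1 (0.15 log units; within the scatter). The core change made a 1.1-fold higher number from compound 2 to compound 3 (0.02 log units; within the scatter). All three numbers therefore sit within the usual scatter of each other, and none can be called more or less toxic than another.

Compound 4 `Cn1c(-c2cccc(Cl)c2)cnc1NC(=O)c1ccc(F)cc1` has not yet been measured. It differs from compound 3 by 4-fluorophenyl in place of 1H-imidazol-2-yl on a carbonyl carbon, the same change as from compound 2 to compound 1, at the same place. Because the earlier step of a 1.4-fold lower number from compound 2 to compound 1 (0.15 log units; within the scatter) stayed within the scatter, the step expected here for compound 4 is a 1.4-fold lower number from compound 3 to compound 4 (0.14 log units; within the scatter). The estimate for compound 4 in this assay is 40000 nM, expected to fall between 20000 nM and 80000 nM.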

Compound 4, half-maximal cytotoxic concentration: > 50000 nM
Compound 4 gave a limit, no number; the forecaster's own chance of this, stated with the estimate: 15%; middle value at least 1.2-fold (0.09 log units) from the limit.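

In this assay compound 4 gives > 50000 nM, which is a limit of the assay and not a number. Going by these compounds alone, the swap of 1H-imidazol-2-yl for 4-fluorophenyl on the carbonyl carbon cannot be read on this second core, so it remains unknown whether that change carries over from the core of compound 2 to the core of compound 3; the one new step that can be read concerns the other change, 3-chlorophenyl in place of 4-chlorophenyl, and it is an at least 1.3-fold higher number from compound 1 to compound 4 (0.13 log units; that floor lies within the scatter). Set beside the earlier step for that same change, this gives no sign that the two cores respond differently, but it does not show that they respond alike either: the same change on two cores in this assay, a 1.1-fold higher number (0.02 log units; within the scatter) from compound 2 to compound 3 and an at least 1.3-fold higher number (0.13 log units; that floor lies within the scatter) from compound 1 to compound 4; the limit leaves it open whether they differ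

On these data alone, the actual number for compound 4 remains open, and with it the size of any effect of the amide swap on this core. Also open, as far as these compounds go, is whether a different group, such as a carboxylic acid or an amine in place of 1H-imidazol-2-yl on the carbonyl carbon, would move the reading in this test beyond the scatter.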